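From diethylamino to 4-methylpiperidin-1-yl at the assay limit

A few compounds are considered here, and "the series" means these few. Any claim that something is new, unique, unknown or untested is made for them only; others in the source may bear on it.

Measured in a functional assay on U-937 cells (Homo sapiens) for antiproliferative activity, read by CCK-8 assay, with a stated time of 24 h; on this read-out higher numbers stand for weaker inhibition and lower numbers for stronger inhibition:
Compound 1 `CN(C)Cc1ccc(NC(=O)NN=C(c2ccccn2)c2ccccn2)cc1`: > 40000 nM
Compound 2 `CCN(CC)Cc1ccc(NC(=O)NN=C(c2ccccn2)c2ccccn2)cc1`: > 40000 nM

Both entries are limits of the assay and not numbers. Compound 2 stands at > 40000 nM, which is such a limit. The evidence so far amounts to the limit of > 40000 nM in this assay, at which 2 of the 2 values shown sit.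

Compound 3 `CC1CCN(Cc2ccc(NC(=O)NN=C(c3ccccn3)c3ccccn3)cc2)CC1` has not yet been measured. It keeps the core of compound 2 but carries 4-methylpiperidin-1-yl in place of diethylamino on a saturated chain carbon bound to an aromatic carbon. Among the compounds with values here, the only measured step at this place is a step that the two limits leave unreadable from compound 1 to compound 2, so it offers no size to carry over. Another limit is the likeliest outcome, and any number that appears is expected close to that limit, on the side of stronger inhibition. The estimate implies an expected at least 1.1-fold lower number from compound 2 to compound 3 (0.05 log units; that floor lies within the scatter). For compound 3 the estimated value in this assay is 35000 nM, with an expected range of 12000 nM to 70000 nM.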

Compound 3, half-maximal inhibitory concentration: > 40000 nM
Compound 3: no number, only a limit; the forecaster's own chance of this, stated with the estimate: 60%; at least 1.1-fold (0.05 log units) between middle value and limit.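

Compound 1, compound 2 and compound 3 all give a limit of the assay rather than a number, so no step among them can be read: the limit of > 40000 nM in this assay, at which 3 of the 3 values shown sit.

Going by these compounds, still open in this assay is how strongly each compound inhibits, and whether the group on the saturated chain carbon matters at all.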